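The source may report more compounds than this note shows. Statements on the series, on what has been measured and on what is new or still open speak of the compounds shown alone.

Three compounds share one core and differ only in the tail that hangs from the ring amine. Compound 1 `CS(=O)(=O)N1CCN(CC(O)CN2CCC(CNC(=O)c3cccc4[nH]cnc34)CC2)CC1` gives 50100 nM in an assay on isolated protein for binding affinity to 5-hydroxytryptamine receptor 3A (Homo sapiens); a higher number here means a weaker inhibitor, a lower number a stronger inhibitor. Compound 2 `CC(C)c1nc2c(C(=O)NCC3CCN(CCN4CCN(S(C)(=O)=O)CC4)CC3)cccc2[nH]1` gives 100000 nM in this assay, and compound 3 `CC(=O)N1CCN(CCN2CCC(CNC(=O)c3cccc4[nH]c(C(C)C)nc34)CC2)CC1` gives 39800 nM in this assay. Compound 3 holds the lowest of the three numbers; its gap to compound 1 lies within the scatter of repeated measurements, so no order between those two can be read, while its gap to compound 2 is real: a 2.5-fold lower number from compound 2 to compound 3 (0.40 log units; beyond the scatter).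

Compound 4 `CC(=O)N(C)CC(O)CN1CCC(CNC(=O)c2cccc3[nH]c(C(C)C)nc23)CC1` takes this further: 2-(acetyl(methyl)amino)-1-hydroxyethyl in place of (4-acetylpiperazin-1-yl)methyl on a saturated chain carbon bound to an amine nitrogen in a ring. Among the compounds with values here, the one measured step in this set swaps a group on the ring amine and leaves the ring in place; the step to compound 4 removes the ring itself and adds a hydroxyl to the chain, a change no measured pair covers. Compound 1 also carries a hydroxyl on its chain, but it differs from compound 3 in more than one place, and its value and that of compound 3 sit within the scatter of each other. With every number here in the weak range and nothing to point in either direction, compound 4 is expected to stay near compound 3, with an estimated step of a 1.3-fold higher number from compound 3 to compound 4 (0.10 log units; within the scatter). Compound 4 is estimated at 50000 nM in this assay, within a range from 20000 nM to 100000 nM.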

Compound 4, inhibition constant: 63100 nM
Compound 4: middle estimate off by 1.3-fold (0.10 log units), on the low side, within the range that was stated.
By their numbers in this assay, from the lowest: compounds 3, 1, 4 and 2 (each within the scatter of the next, the first and the last beyond it).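

Replacing (4-acetylpiperazin-1-yl)methyl with the open-chain 2-(acetyl(methyl)amino)-1-hydroxyethyl on a saturated chain carbon bound to an amine nitrogen in a ring gives a 1.6-fold higher number from compound 3 to compound 4 (0.20 log units; within the scatter) in this assay. Set against the methylsulfonyl-bearing partner, the same position gives a 1.6-fold lower number from compound 2 to compound 4 (0.20 log units; within the scatter), so compound 4 cannot be told apart from either of two compounds that do differ from each other, and at this position the six-membered non-aromatic ring can be exchanged for an open chain with no readable shift in this assay. Nothing available here bears on why this result came out as it did.

The exchange removes the ring and brings in a hydroxyl at the same time, so the compounds shown cannot separate what each of those two edits contributes on its own. Also open is whether a different end to the chain, such as a primary amine, a carboxylic acid or a longer chain, would move the value beyond the scatter, since all the tails shown end in an acetyl or methylsulfonyl group.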